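The source may hold more compounds than are shown below. What is called first, only, known or untested is meant among the compounds shown, and "the series" means these compounds.

Compound 1 `COc1cccc(NC(=O)COc2cc(C)nc3ccc(OC)cc23)c1` and compound 2 `COc1ccc2nc(C)cc(OCC(=O)Nc3ccccn3)c2c1` both sit at the ceiling of the read-out. In a toxicity assay on HepG2 cells (Homo sapiens) for inhibition, read by CellTiter-Glo, with a stated time of 48 h (on this read-out lower numbers stand for stronger inhibition and higher numbers for weaker inhibition), compound 1 reaches only the assay limit of > 100000 nM. In this assay compound 2 likewise reaches only the assay limit of > 100000 nM. The step that the two limits leave unreadable from compound 1 to compound 2 therefore cannot be sized, since the limit of > 100000 nM in this assay, at which 2 of the 2 values shown sit, holds both values. Compound 3 `COc1ccc2nc(C)cc(OCC(=O)NC3CONC3=O)c2c1` differs from compound 2 by a group of 6 heavy atoms (3 carbon, 1 nitrogen, 2 oxygen; one five-membered non-aromatic ring with 2 hetero atoms) in place of a group of 6 heavy atoms (5 carbon, 1 nitrogen; one six-membered aromatic ring with 1 hetero atom), on an amide-type nitrogen. For the measured compounds named here, no measured step bears on this exchange. For compound 3 a step of a number no higher from compound 2 to compound 3 (the limit leaves the size open) is expected, none beyond the scatter, most likely again only a limit. Compound 3 is estimated at 100000 nM, within 30000 nM to 300000 nM.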

Compound 3, half-maximal inhibitory concentration: > 100000 nM
Compound 3: only a limit was reported (the forecaster's own chance of this, stated with the estimate: 85%); the middle value lies on the limit itself.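

No step can be read among compound 1, compound 2 and compound 3, since all three values are limits: the limit of > 100000 nM in this assay, at which 3 of the 3 values shown sit. From the compounds shown here alone, whether any group on the amide-type nitrogen alters inhibition in this assay remains open.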